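A few compounds are considered here, and "the series" means these few. Any claim that something is new, unique, unknown or untested is made for them only; others in the source may bear on it.

Measured compounds in a toxicity assay on WI-38 cells (Homo sapiens) for cytotoxicity, read by MTT assay, with a stated time of 48 h; a higher number here means a weaker inhibitor, a lower number a stronger inhibitor:
compound 1 `O=C(/C=C/c1ccc2c(c1)B(O)OC2)c1ccco1` gives 59000 nM.
compound 2 `Cn1cccc1C(=O)/C=C/c1ccc2c(c1)B(O)OC2` gives > 100000 nM, which is a limit of the assay and not a number.
compound 3 `O=C(/C=C/c1ccc2c(c1)B(O)OC2)c1ccc(F)cc1` gives 7600 nM.

Compound 3 holds the lowest of the two numbers; the nearest is compound 1, with a 7.8-fold lower number from compound 1 to compound 3 (0.89 log units; beyond the scatter), while compound 2 gives only a limit. The measured steps all swap the group on the carbonyl carbon: an at least 1.6-fold higher number from compound 1 to compound 2 (0.22 log units; that floor lies within the scatter), a 7.8-fold lower number from compound 1 to compound 3 (0.89 log units; beyond the scatter), an at least 13-fold lower number from compound 2 to compound 3 (1.11 log units; beyond the scatter). Compound 4 `CCc1ccc(C(=O)/C=C/c2ccc3c(c2)B(O)OC3)cc1` keeps the ring of compound 3 and changes (ethyl in place of fluoro on an aromatic carbon). Going by the values given here, no measured step touches a substituent on that ring, so none bears directly on this change, and the expectation rests on compound 3 alone. For compound 4 a step of a 1.1-fold lower number from compound 3 to compound 4 (0.04 log units; within the scatter) is expected in this assay, that is, none beyond the scatter. The estimate for compound 4 is 7000 nM, with a range of 2500 nM to 25000 nM.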

Compound 4, half-maximal inhibitory concentration: 20600 nM
For compound 4 the middle estimate is 2.9-fold (0.47 log units) below the measured one; the measured number falls inside the stated range.
By their numbers in this assay, from the lowest: compound 3; then compound 4; then compound 1. At a limit, above all of these: compound 2.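

Ethyl in place of fluoro, on an aromatic carbon para to a large group, gives a 2.7-fold higher number from compound 3 to compound 4 (0.43 log units; beyond the scatter) in this assay. Going by these compounds alone, a substituent on this ring therefore moves the number, which the earlier steps, all made at the group on the carbonyl carbon, could not show. Nothing measured here accounts for the direction of this step.

From the compounds shown here alone, with a single pair at this position, it remains open whether the rise belongs to ethyl alone or to replacing fluoro generally. An amine, a carboxylic acid or a longer chain on the same carbon would separate these readings.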